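A few compounds are considered here, and "the series" means these few. Any claim that something is new, unique, unknown or untested is made for them only; others in the source may bear on it.

Compound 1 `CC(C)COC(=O)N1CCN(C(=O)c2nc(Nc3cc(C4CC4)[nH]n3)c3cc(Cl)ccc3n2)C[C@H]1C`: 61.1%
Compound 2 `CC(OC(=O)N1CCN(C(=O)c2nc(Nc3cc(C4CC4)[nH]n3)c3cc(Cl)ccc3n2)C[C@H]1C)OC(=O)C(C)(C)C`: 66.3%

For the measured compounds named here, in an ADME assay on S9 fraction from liver (Rattus norvegicus), read by LC-MS, with a stated time of 60 min, at 37 degrees C (a lower number here means that less of the compound is left, a higher number that more of the compound is left), compound 2 gives 66.3%, and the only comparison so far is the step of a number 5.2 percentage points higher from compound 1 to compound 2 (within the scatter). Compound 3 `C[C@@H]1CN(C(=O)c2nc(Nc3cc(C4CC4)[nH]n3)c3cc(Cl)ccc3n2)CCN1C(=O)OCc1ccccc1` differs from compound 2 at the same place: benzyl in place of 1-(((tert-butyl)carbonyl)oxy)ethyl on an oxygen next to a carbonyl group. Going by the values given here, the one measured step at that oxygen stayed within the scatter, and nothing measured holds the benzyl group itself, so the expectation rests on that single step alone. The step from compound 2 to compound 3 is therefore expected to be a number 6.3 percentage points lower from compound 2 to compound 3 (within the scatter), none beyond the scatter. For compound 3 the estimated value is 60%, between 44% and 76%.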

Compound 3, percent of the compound remaining: 45.6%
The estimate for compound 3 lay 14.4 percentage points above the measured number; the measured number falls inside the stated range.
By their numbers in this assay, from the lowest: compound 3; then compounds 1 and 2 (each within the scatter of the next).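

Changing the group on this oxygen can shift how much compound is left in this assay after all: benzyl gives a number 20.7 percentage points lower from compound 2 to compound 3 (beyond the scatter) and also a number 15.5 percentage points lower from compound 1 to compound 3 (beyond the scatter) as its two steps. For the compounds shown here, compounds 1 and 2 carry very different groups without an aromatic ring and stay within the scatter of each other, so the first clear separation comes with benzyl, the only group here with such a ring. Nothing measured here accounts for this change.
From the compounds shown here alone, whether the aromatic ring itself matters stays open. Cyclohexylmethyl, the saturated counterpart of benzyl, on the same oxygen could help to tell.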